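This account rests on a few compounds, and the source may have more. Where it says the series, first, only, none or still open, it means among the compounds named here.

Measured so far: compound 1 `[O-]/[N+](=C\c1cn(-c2ccccc2)nn1)Cc1ccccc1`, compound 2 `[O-]/[N+](=C\c1cn(CCC(F)(F)C(F)(F)C(F)(F)C(F)(F)C(F)(F)C(F)(F)F)nn1)Cc1ccccc1` and compound 3 `CC(C)(C)/[N+]([O-])=C/c1cn(-c2ccccc2)nn1`.

In a functional assay on A549 cells (Homo sapiens) for inhibition, read by MTT assay, with a stated time of 24 h (on this read-out higher numbers stand for weaker inhibition and lower numbers for stronger inhibition), compound 1 reaches only the limit > 100000 nM, which is a limit and not a number. Compound 2 likewise reaches only the limit > 100000 nM in this assay. Compound 3 gives 17400 nM in this assay. The change from compound 1 to compound 3 is tert-butyl in place of benzyl on a double-bonded nitrogen, and it produced an at least 5.7-fold lower number from compound 1 to compound 3 (0.75 log units; beyond the scatter); the step can be given only as a lower bound because of the limit of > 100000 nM in this assay, at which 2 of the 3 values shown sit. How the core of compound 2 differs from the core of compound 1 is not broken down here.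

Compound 4 `CC(C)(C)/[N+]([O-])=C/c1cn(CCC(F)(F)C(F)(F)C(F)(F)C(F)(F)C(F)(F)C(F)(F)F)nn1` has not yet been measured in this assay. It arises from compound 2 by tert-butyl in place of benzyl on a double-bonded nitrogen, the same change as that from compound 1 to compound 3. The step from compound 2 to compound 4 is expected to be an at least 3.3-fold lower number from compound 2 to compound 4 (0.52 log units; beyond the scatter), resting on the step of an at least 5.7-fold lower number from compound 1 to compound 3 (0.75 log units; beyond the scatter) seen between compound 1 and compound 3. For compound 4 the expected value in this assay is 30000 nM, between 8000 nM and 100000 nM.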

Compound 4, half-maximal inhibitory concentration: 11500 nM
Compound 4: the middle estimate sits 2.6-fold (0.42 log units) above what was measured; the range from low to high includes it.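

Tert-butyl in place of benzyl on a double-bonded nitrogen again lowers the number in this assay, with an at least 8.6-fold lower number from compound 2 to compound 4 (0.93 log units; beyond the scatter). The change therefore carries over in direction from the core of compound 1 to the core of compound 2, and in both pairs the step lies beyond the scatter: the same change on two cores in this assay, an at least 5.7-fold lower number (0.75 log units; beyond the scatter) from compound 1 to compound 3 and an at least 8.6-fold lower number (0.93 log units; beyond the scatter) from compound 2 to compound 4; the limit leaves it open whether they differ. This does not show the true size of either step, nor whether one core responds more strongly than the other, since both steps start from a limit and not from a number: the limit of > 100000 nM in this assay, at which 2 of the 4 values shown sit.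

The compounds shown leave open whether another alkyl group on a double-bonded nitrogen, such as isopropyl or cyclohexyl, would lower the number as tert-butyl does. They also leave open whether the change would carry over to further cores, for instance one with a shorter chain in place of the fluorinated chain of compound 4, or one with a methoxy group on the phenyl ring of compound 3.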